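From an Aryl Amide to an Ethynyl Amide

This account rests on a few compounds, and the source may have more. Where it says the series, first, only, none or still open, it means among the compounds named here.

In a functional assay on KETR3 cells (Homo sapiens) for inhibition, read by MTT assay, with a stated time of 120 h (on this read-out higher numbers stand for weaker inhibition and lower numbers for stronger inhibition), compound 1 (`CNC(=O)/C=C/c1ccc(NC(=O)Nc2ccc(Cl)c(C(F)(F)F)c2)cc1`) reads 21200 nM and compound 2 (`CC(NC(=O)C#Cc1ccc(NC(=O)Nc2ccc(Cl)c(C(F)(F)F)c2)cc1)c1ccccc1`) reads 21400 nM on the same read-out. Compound 3 (`CNC(=O)c1cccc(-c2ccc(NC(=O)Nc3ccc(Cl)c(C(F)(F)F)c3)cc2)c1`) reads 39300 nM and stands within the scatter of both, so the three numbers form one narrow group.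

The next comparison leads to compound 4 (`CNC(=O)C#Cc1ccc(NC(=O)Nc2ccc(Cl)c(C(F)(F)F)c2)cc1`), which has 2-(methylcarbamoyl)ethynyl in place of 3-(methylcarbamoyl)phenyl on an aromatic carbon, para to a large group (2-(methylcarbamoyl)ethynyl in place of 3-(methylcarbamoyl)phenyl on an aromatic carbon).

Within the data shown here, the one measured step at this place is a 1.9-fold higher number from compound 1 to compound 3 (0.27 log units; within the scatter) and it comes with 3-(methylcarbamoyl)phenyl in place of 2-(methylcarbamoyl)ethenyl. Among the measured compounds shown here, that exchange is close to the one at hand, but it is not the same, and no measured pair isolates the ethynyl group on its own. Compound 2 also carries a triple bond in that chain, with a different group on the amide nitrogen, and its 21400 nM does not depart from the others.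

With so small a measured step, no change beyond the scatter is expected. The estimate is therefore a 1.6-fold lower number from compound 3 to compound 4 (0.21 log units; within the scatter) and it remains an expectation only. For compound 4 the estimated value is 24000 nM (expected range 11000 nM to 48000 nM).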

Compound 4, half-maximal inhibitory concentration: 24700 nM
Beside the measured number, compound 4's estimate is 1.0-fold (0.01 log units) below it; the range from low to high includes it.
By their numbers in this assay, from the lowest: compounds 1, 2, 4 and 3 (each within the scatter of the next).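

In this assay, the 3-(methylcarbamoyl)phenyl group gives way to the much smaller, ring-free 2-(methylcarbamoyl)ethynyl group with no change beyond the scatter (a 1.6-fold lower number from compound 3 to compound 4 (0.20 log units; within the scatter)), so an aromatic ring in this substituent is not required for a reading of this size. Among these compounds, the compounds now also give the first direct comparisons of the triple bond with the double bond (a 1.2-fold higher number from compound 1 to compound 4 (0.07 log units; within the scatter)) and of methyl with 1-phenylethyl on the amide nitrogen (a 1.2-fold higher number from compound 2 to compound 4 (0.06 log units; within the scatter)), and both steps lie within the scatter, so neither exchange separates these compounds on this read-out. No evidence at hand explains why these exchanges leave the readings in one narrow group.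

Because all four compounds share the same core and the same narrow range, the compounds shown leave open whether any change at this position can move the reading beyond the scatter. On these data alone, it also remains open how an amine or a carboxylic acid in place of the amide, or a longer chain carrying that amide, would read in this assay.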